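This account rests on a few compounds, and the source may have more. Where it says the series, first, only, none or still open, it means among the compounds named here.

Measured compounds:
- compound 1 `CCN(CC)CCNc1nc(NCc2ccco2)c2ccccc2n1`: 28.5%
- compound 2 `CCCCNc1nc(NCc2ccco2)c2cc(F)ccc2n1`: 75.4%
- compound 3 `CN(C)CCNc1nc(NCc2ccco2)c2ccccc2n1`: 20%

In a functional assay on DU-145 cells (Homo sapiens) for cytotoxicity, read by MTT assay, with a stated time of 2 days, tested at 10 uM (a higher number here means more inhibition at the concentration tested (going by the name of the read-out), a lower number less inhibition), compound 3 gives the lowest of the three numbers. Its nearest neighbour is compound 1, a number 8.5 percentage points lower from compound 1 to compound 3 (within the scatter), a gap within the scatter; compound 2 lies furthest away, beyond the scatter. Compound 4 `CCCCNc1nc(NCc2ccco2)c2ccccc2n1` has not yet been measured. It differs from compound 3 by ethyl in place of dimethylamino on a saturated chain carbon, two bonds along the chain from a nitrogen on an aromatic ring, so that a 2-(dimethylamino)ethyl chain becomes a butyl chain. Within the data shown here, the only measured step of this kind, the one from compound 1 to compound 3, swaps one amino group for another and stays within the scatter, so it says little about removing the nitrogen altogether. Compound 2 carries the same butylamino group as compound 4, though its shared core also bears a fluorine, and in this assay compound 2 gives 75.4%. Compound 3, by contrast, gives 20%. On that basis a rise beyond the scatter is expected, a number 35 percentage points higher from compound 3 to compound 4 (beyond the scatter), with the fluorine left as an unknown. Compound 4 is therefore estimated at 55%, within a range from 30% to 80%.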

Compound 4, a percentage reported as inhibition, at one concentration (the size of the read-out at that concentration, not a potency): 89.9%
Beside the measured number, compound 4's estimate is 34.9 percentage points below it, outside the stated range (above it).
By their numbers in this assay, from the lowest: compounds 3 and 1 (each within the scatter of the next); then compound 2; then compound 4.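

In this assay, the earlier step at this position only exchanged one amine for another, whereas taking the amine away altogether, so that a 2-(dimethylamino)ethyl chain becomes a butyl chain, gives a number 69.9 percentage points higher from compound 3 to compound 4 (beyond the scatter), and the same kind of change starting from the diethylamino chain gives a number 61.4 percentage points higher from compound 1 to compound 4 (beyond the scatter). So both amine-bearing chains shown sit far lower than the butyl chain on the same core, and the nitrogen at the end of the chain emerges as the change that matters most here, while the fluoro on the core counts for less: hydrogen in place of fluoro gives a number 14.5 percentage points higher from compound 2 to compound 4 (beyond the scatter). No measurement is available that would explain why the number climbs when the chain loses its amine.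

The compounds shown leave open whether the high number is particular to butyl or would also hold for a longer chain such as hexyl, or for a chain ending in a methoxy group or a hydroxyl group instead of an amine. They also leave open what the fluoro group does on the core when the chain ends in dimethylamino or diethylamino.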